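A few compounds are considered here, and "the series" means these few. Any claim that something is new, unique, unknown or untested is made for them only; others in the source may bear on it.

Compound 1 `Nc1cc(N)c2nc(-c3ccccc3)c(Oc3ccc(Cl)c(Cl)c3)nc2c1`, compound 2 `Nc1cc(N)c2nc(-c3ccccc3)c(NCc3ccc(Cl)c(Cl)c3)nc2c1` and compound 3 `COc1ccc(CNc2nc3cc(N)cc(N)c3nc2-c2ccccc2)cc1OC` share one core and differ only in the group attached to it. In a functional assay on DU-145 cells (Homo sapiens) for inhibition, read by sulforhodamine B assay, with a stated time of 48 h (on this read-out lower numbers stand for higher toxicity in this test and higher numbers for lower toxicity in this test), compound 2 gives 69200 nM. For compound 1 this assay reports only a limit, < 100000 nM. Compound 3 likewise stands only at a limit, < 100000 nM, so the step that the limit leaves unreadable from compound 2 to compound 3 cannot be read; the limit of < 100000 nM in this assay, at which 2 of the 3 values shown sit, marks where most of these values sit. Compound 4 `Nc1cc(N)c2nc(-c3ccccc3)c(NCc3ccc(F)cc3)nc2c1` differs from compound 3 by 4-fluorophenyl in place of 3,4-dimethoxyphenyl on a saturated chain carbon bound to a nitrogen on an aromatic ring. Among the measured compounds shown here, no measured step covers this change, and the one readable value, that of compound 2, shows only weak toxicity. Compound 4 is therefore expected to remain weak, with an estimated 80000 nM, between 30000 nM and 200000 nM, the estimated step that the limit leaves unreadable from compound 3 to compound 4 being of uncertain size.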

Compound 4, concentration lethal to 50% of the cells: 9770 nM
For compound 4 the middle estimate is 8.2-fold (0.91 log units) above the measured one; the measured number lies below the stated range.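

With 4-fluorophenyl in place of 3,4-dichlorophenyl on a saturated chain carbon bound to a nitrogen on an aromatic ring, this assay shows a 7.1-fold lower number from compound 2 to compound 4 (0.85 log units; beyond the scatter). Among the compounds shown here, this is the first readable step, and it shows that toxicity in this test responds to the ring carried at this position. The steps to compound 4 from compound 1 and compound 3 cannot be read, since each of those two compounds stands only at a limit: the limit of < 100000 nM in this assay, at which 2 of the 4 values shown sit.

With only these compounds, the role of the fluorine itself remains unclear. As far as these compounds go, it also remains open how a plain phenyl group or an amine would read at this position.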